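The source may hold more compounds than are shown below. What is called first, only, known or untested is meant among the compounds shown, and "the series" means these compounds.

Compound 1 `COc1cc(-c2nnc3n2NC(c2ccco2)C(C(=O)c2ccc(F)cc2)S3)cc(OC)c1OC`: in a functional assay on HepG2 cells (Homo sapiens) for cytotoxicity, read by MTT assay, with a stated time of 48 h (on this read-out lower numbers stand for stronger inhibition and higher numbers for weaker inhibition), compound 1 gives > 100000 nM, a limit of the assay.
Compound 2 `COc1cc(-c2nnc3n2NC(c2ccco2)C(C(=O)c2ccc(C)cc2)S3)cc(OC)c1OC`: in this assay compound 2 gives 17400 nM.

For the measured compounds named here, compound 2 holds the only number reported in this assay; the other value is a limit. Compound 3 `COc1cc(-c2nnc3n2NC(c2ccco2)C(C(=O)c2ccc(F)c(F)c2)S3)cc(OC)c1OC` carries 3,4-difluorophenyl in place of 4-methylphenyl on a carbonyl carbon. Going by the values given here, the single measured step bears on this change in reverse: an at least 5.7-fold lower number from compound 1 to compound 2 (0.75 log units; beyond the scatter), where compound 1 sits at the limit of > 100000 nM in this assay, at which 1 of the 2 values shown sits. Returning fluorine to this ring is therefore expected to raise the number, and compound 3 is estimated at 70000 nM (range 25000 nM to 200000 nM), a step of a 4.0-fold higher number from compound 2 to compound 3 (0.60 log units; beyond the scatter), with a fair chance that only a limit is reported.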

Compound 3, half-maximal inhibitory concentration: 52400 nM
The estimate for compound 3 lay 1.3-fold (0.13 log units) above the measured number; measured number inside the range.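

On a carbonyl carbon, 3,4-difluorophenyl in place of 4-methylphenyl gives a 3.0-fold higher number from compound 2 to compound 3 (0.48 log units; beyond the scatter) in this assay, so 4-methylphenyl remains the better of the two groups with a measured number, while a ring carrying fluorine can still give a number rather than a limit. The added fluoro gives an at least 1.9-fold lower number from compound 1 to compound 3 (0.28 log units; that floor lies within the scatter), and this floor alone shows no real gain: the limit of > 100000 nM in this assay, at which 1 of the 3 values shown sits.

As far as these compounds go, whether an amine, a carboxylic acid or a longer chain on this ring would match or pass compound 2 stays open.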